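A few compounds are considered here, and "the series" means these few. Any claim that something is new, unique, unknown or untested is made for them only; others in the source may bear on it.

Within the data shown here, compound 2 `O=C(Nc1ccc(S(=O)(=O)Nc2ccccc2)cc1)c1ccc(Br)cc1F` holds the lower of the two numbers so far in a functional assay on HEK293 cells for agonist activity at probable G-protein coupled receptor 27 (Homo sapiens), read by a luciferase reporter and beta-arrestin recruitment, with a stated time of 10 min; a lower number here means that less compound is needed, a higher number that more compound is needed for the effect: compound 2 gives 479 nM, whereas compound 1 `O=C(Nc1ccc(S(=O)(=O)Nc2ccccc2)cc1)c1ccc(Cl)cc1F` gives 3980 nM. Among the measured compounds shown here, the single step that joins them is an 8.3-fold lower number from compound 1 to compound 2 (0.92 log units; beyond the scatter), a modest gain from exchanging one halogen for the next heavier one. Compound 3 `O=C(Nc1ccc(S(=O)(=O)Nc2ccccc2)cc1)c1ccc(I)cc1F` continues that line, with the change (iodo in place of bromo on an aromatic carbon). For the measured compounds named here, only one measured step bears on this, and it points toward a lower number; with nothing else to go on, the account expects the same direction but a smaller move, since one step gives no basis for assuming the gain repeats in full. Compound 3 is therefore estimated at 250 nM in this assay, with a range from 80 nM to 800 nM. That estimate means an expected step of a 1.9-fold lower number from compound 2 to compound 3 (0.28 log units; within the scatter), beyond the scatter only at its upper end.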

Compound 3, half-maximal effective concentration: 5130 nM
The estimate for compound 3 lay 21-fold (1.31 log units) below the measured number; measured number above the stated range.
By their numbers in this assay, from the lowest: compound 2; then compounds 1 and 3 (each within the scatter of the next).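

In this assay, the exchange of bromo for iodo runs against the direction of the earlier step, with an 11-fold higher number from compound 2 to compound 3 (1.03 log units; beyond the scatter), so moving to the heavier halogen at this position does not lower the number steadily. Chloro and iodo sit level, with a 1.3-fold higher number from compound 1 to compound 3 (0.11 log units; within the scatter), which leaves compound 2 alone at the low end: among these three halogens the position shows a turn at bromo rather than a slope, and a single-atom exchange here can shift the number in either direction. Nothing measured here explains this reversal. As far as these compounds go, it remains open whether a non-halogen group at this place, such as methyl, methoxy, trifluoromethyl or nitrile, would match bromo or fall with chloro and iodo. Also open, from the compounds shown here alone, is whether bromo would keep its lead over chloro and iodo with the fluoro group replaced by hydrogen.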